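The source may hold more compounds than are shown below. What is called first, only, known or untested is meant among the compounds shown, and "the series" means these compounds.

Among the compounds with values here, in a functional assay on MCF7 cells (Homo sapiens) for antiproliferative activity, read by MTT assay, with a stated time of 72 h (on this read-out lower numbers stand for stronger inhibition and higher numbers for weaker inhibition), compound 2 `Cc1cc(N2CCCCC2)nc2ccc(NC(=O)c3ccc(Cl)c(Cl)c3)cc12` gives 31100 nM, the second highest of the three numbers so far. Compound 1 `CCN1CCN(c2cc(C)c3cc(NC(=O)c4ccco4)ccc3n2)CC1` gives 41200 nM, which lies within the scatter of compound 2; compound 3 `CCN1CCN(c2cc(C)c3cc(NC(=O)c4ccccc4)ccc3n2)CC1` gives 14200 nM, which lies beyond it. Within the data shown here, the one measured step, a 2.9-fold lower number from compound 1 to compound 3 (0.46 log units; beyond the scatter), changes the group on the carbonyl carbon and leaves the amine untouched. Compound 4 `CCN(CC)c1cc(C)c2cc(NC(=O)c3ccc(Cl)c(Cl)c3)ccc2n1` differs from compound 2 at another place: diethylamino in place of piperidin-1-yl on an aromatic carbon. Among the measured compounds shown here, no measured step covers this exchange, and the step in hand does not touch the place where it occurs, so a step no larger than the scatter in this assay is expected for a 1.0-fold lower number from compound 2 to compound 4 (0.00 log units; within the scatter), with no fixed direction. The number expected for compound 4 is therefore 31000 nM, with a range from 12000 nM to 80000 nM.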

Compound 4, half-maximal inhibitory concentration: > 50000 nM
Compound 4: no number, only a limit; the forecaster's own chance of this, stated with the estimate: 10%; middle value at least 1.6-fold (0.20 log units) away from the limit.
By their numbers in this assay, from the lowest: compound 3; then compounds 2 and 1 (each within the scatter of the next). At a limit, above all of these: compound 4.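

Within the data shown here, replacing piperidin-1-yl with the open-chain diethylamino on the aromatic carbon next to the ring nitrogen gives the first reading at this position, an at least 1.6-fold higher number from compound 2 to compound 4 (0.20 log units; that floor lies within the scatter). This excludes a gain in inhibition from the exchange, but the floor does not separate the change from the scatter. Compound 4 stands at a limit of the assay, not at a number: the limit of > 50000 nM in this assay, at which 1 of the 4 values shown sits.

Going by these compounds, the true size of the step remains open. So does the outcome at this position with a morpholin-4-yl group or a primary amine in place of diethylamino.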